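Chloro in Place of Methyl: Expected Cell Tolerance

The source may report more compounds than this note shows. Statements on the series, on what has been measured and on what is new or still open speak of the compounds shown alone.

Measured compounds:
Compound 1, `Cc1cccc(C2CC(c3ccc(Oc4ccccc4)cc3)=NN2c2ccc(S(N)(=O)=O)cc2)c1`, gives 35000 nM in an ADME assay on MT4 cells (Homo sapiens) for cytotoxicity, read by MTT assay, with a stated time of 96 h; a higher number here means that more compound is tolerated, a lower number that less compound is tolerated.
Compound 2, `Cc1ccc(C2CC(c3ccc(OCc4ccccc4)cc3)=NN2c2ccc(S(N)(=O)=O)cc2)cc1`, gives 35000 nM in this assay.

Compound 1 stands level with compound 2 at the digits shown; the two values lie within the usual scatter of each other, so no difference between them can be claimed. Among the compounds with values here, both readings sit at the same point, and nothing more can be said of their pair, since no single-point step between them is given.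

Compound 3, `NS(=O)(=O)c1ccc(N2N=C(c3ccc(Oc4ccccc4)cc3)CC2c2cccc(Cl)c2)cc1`, differs from compound 1 in one place: chloro in place of methyl on an aromatic carbon. The rest of the shared core is unchanged.

Within the data shown here, no measured step between two compounds is available to set the size of such a swap. With compound 1 and compound 2 both tolerated to the same degree, the expectation for compound 3 in this assay is a step of no size beyond the scatter, written as no change at the digits printed from compound 1 to compound 3 (within the scatter). Compound 3 is therefore estimated at 35000 nM in this assay, with a range from 17000 nM to 70000 nM.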

Compound 3, half-maximal cytotoxic concentration: 8000 nM
The estimate for compound 3 lay 4.4-fold (0.64 log units) above the measured number, and the stated range ends above it.
By their numbers in this assay, from the lowest: compound 3; then compounds 1 and 2 (each within the scatter of the next).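

Chloro in place of methyl, the change from 3-methylphenyl to 3-chlorophenyl, gives a 4.4-fold lower number from compound 1 to compound 3 (0.64 log units; beyond the scatter) in this assay. This shows that the cells respond to what this aromatic carbon carries, since one heavy atom replaces another, no ring, hydrogen-bond donor, hydrogen-bond acceptor or net charge enters or leaves, and still less of compound 3 is tolerated, by a modest step. Compound 1 and compound 2 could not show this, as they differ in more than one place, and no measurement at hand says why this single swap lowers the number.

As far as these compounds go, whether this position responds in the same way to other groups, such as an amine, a carboxylic acid or a longer chain, remains open, so the result cannot yet be read as a trend across substituents. Also open, from the compounds shown here alone, is whether chloro in place of methyl would bring a similar step on the core of compound 2, where the methyl stands at a different place and the rest of the molecule differs as well.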